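The compounds below may be only part of what the source reports. "The series", "measured", "known", "first", "only" and "open" are said of these compounds alone.

Measured compounds:
compound 1 `COCCOC(=O)C(O)Cn1cnc2c(N)ncnc21` > 400 ug/mL
compound 2 `CCCCCOC(=O)C(O)Cn1cnc2c(N)ncnc21` 200 ug/mL
compound 3 `Nc1ncnc2c1ncn2CC(O)C(=O)OCc1ccco1` 40 ug/mL

Compound 3 `Nc1ncnc2c1ncn2CC(O)C(=O)OCc1ccco1` gives the lowest of the two numbers in a functional assay on Vero cells (Chlorocebus sabaeus) for cytotoxicity; a higher number here means that more compound is tolerated, a lower number that less compound is tolerated. The nearest measured value is that of compound 2, which sits a 5.0-fold lower number from compound 2 to compound 3 (0.70 log units; beyond the scatter). Compound 1 gives no number in this assay but only a limit, > 400 ug/mL.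

Compound 4 `CCOC(=O)C(O)Cn1cnc2c(N)ncnc21` differs from compound 3 in one place: methyl in place of furan-2-yl on a saturated chain carbon bound to an oxygen next to a carbonyl group.

The measured steps that bear on this change both run towards the furan-2-yl group: a 5.0-fold lower number from compound 2 to compound 3 (0.70 log units; beyond the scatter) and an at least 10-fold lower number from compound 1 to compound 3 (1.00 log units; beyond the scatter). The change from compound 3 to compound 4 runs the other way, swapping the furan-2-yl for a methyl, so compound 4 is expected to come out with a clearly higher number in this assay, with the step estimated as a 10-fold higher number from compound 3 to compound 4 (1.00 log units; beyond the scatter). Because compound 1 reached the limit (the limit of > 400 ug/mL in this assay, at which 1 of the 3 values shown sits), there is a real chance that compound 4 also reports only a limit. The expected value for compound 4 is 400 ug/mL, with a range from 200 ug/mL to 800 ug/mL.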

Compound 4, minimum cytotoxic concentration: > 400 ug/mL
Compound 4: a limit, no number (the forecaster's own chance of this, stated with the estimate: 50%); the middle value lies on the limit itself.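

In this assay compound 4 gives > 400 ug/mL, which is a limit and not a number, so its steps give only floors: the limit of > 400 ug/mL in this assay, at which 2 of the 4 values shown sit.

Among the compounds shown here, putting methyl in place of furan-2-yl gives an at least 10-fold higher number from compound 3 to compound 4 (1.00 log units; beyond the scatter), a direct reading of this change at the saturated chain carbon bound to an oxygen next to a carbonyl group, where the earlier steps had only approached furan-2-yl from other groups. Removing the propyl gives an at least 2.0-fold higher number from compound 2 to compound 4 (0.30 log units; that floor lies within the scatter), so the shorter ethoxy chain cannot be firmly separated from the pentyl chain, and the step between compound 1 and compound 4 cannot be read.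

The compounds shown leave open how far above the limit compound 1 and compound 4 lie. They also leave open whether the lower number belongs to furan-2-yl itself or to any ring here, a question on which a phenyl group at this place would bear.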